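This account rests on a few compounds, and the source may have more. Where it says the series, first, only, none or still open, it means among the compounds named here.

Of the compounds shown here, three built on a shared core have been measured in an assay on isolated protein for inhibition of Amine oxidase [flavin-containing] B (Homo sapiens), read by fluorescence and Amplex Red, with stated times of 15 min and 20 min; on this read-out lower numbers stand for stronger inhibition and higher numbers for weaker inhibition. Compound 1 `COc1cccc(/C=N/c2ccc(OCc3ccccc3)cc2)c1O` gives 6500 nM, compound 2 `Cc1ccc(/C=N/c2ccc(OCc3ccccc3)cc2)c(O)c1` gives 24400 nM, and compound 3 `Oc1ccc(/C=N/c2ccc(OCc3ccccc3)cc2)c(O)c1O` gives 1730 nM. Of these three numbers compound 2 stands highest; compound 1 lies nearest to it and compound 3 furthest from it, and both gaps exceed the usual scatter of such measurements. Compound 4 `Oc1ccc(Br)cc1/C=N/c1ccc(OCc2ccccc2)cc1` has not yet been measured in this assay. It differs from compound 2 in a single place: 5-bromo-2-hydroxyphenyl in place of 2-hydroxy-4-methylphenyl on a carbon with a double bond to nitrogen. Among the measured compounds shown here, no pair of measured compounds shows a change of this kind, so there is no measured step from which to read the direction, and any expectation rests on where compound 2 sits among the three numbers. Given that the other two measured compounds, compound 1 and compound 3, both lie below compound 2, the step from compound 2 to compound 4 is expected to be modest, a 2.4-fold lower number from compound 2 to compound 4 (0.39 log units; beyond the scatter), toward a lower number. Compound 4 is accordingly estimated at 10000 nM, with a range from 3000 nM to 35000 nM.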

Compound 4, half-maximal inhibitory concentration: 31700 nM
For compound 4 the middle estimate is 3.2-fold (0.50 log units) below the measured one, within the range that was stated.
By their numbers in this assay, from the lowest: compound 3; then compound 1; then compounds 2 and 4 (each within the scatter of the next).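

In this assay, exchanging 2-hydroxy-4-methylphenyl for 5-bromo-2-hydroxyphenyl gives a 1.3-fold higher number from compound 2 to compound 4 (0.11 log units; within the scatter), so the two compounds cannot be told apart on this read-out. Among the compounds shown here, this is the first measured step at this position, and it shows that this exchange of one substituted phenyl group for another, with the same count of heavy atoms, leaves the number unchanged within the scatter. Nothing at hand explains this result.

The compounds shown leave open whether an amine or a carboxylic acid on this phenyl ring, in place of the bromine or the methyl, would shift the number beyond the scatter. They also leave open whether the same exchange would again read alike on a different core.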